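The source may hold more compounds than are shown below. What is called first, only, known or untested is meant among the compounds shown, and "the series" means these compounds.

Going by the values given here, compound 2 `Cn1nnnc1SCC(=O)Nc1ccc(-c2nc(-c3ccccc3)c(-c3ccccc3)n2C)cc1` stands highest of the two compounds measured so far in a functional assay on MCF7 cells (Homo sapiens) for cytotoxicity, read by MTT assay, with a stated time of 24 h, tested at 16 ug/mL (a higher number here means a stronger effect of the compound at the concentration tested, a lower number a weaker effect), where compound 2 gives 63.7%. Its nearest neighbour is compound 1 `Cn1c(-c2ccc(NC(=O)CSc3nc4cc(Cl)ccc4o3)cc2)nc(-c2ccccc2)c1-c1ccccc1`, which in this assay gives 40%; the step of a number 23.7 percentage points higher from compound 1 to compound 2 (beyond the scatter) rests on the exchange of the group on the sulfur. Compound 3 `Cn1c(-c2ccc(NC(=O)CSC3=NCCS3)cc2)nc(-c2ccccc2)c1-c1ccccc1` has not yet been measured in this assay. It differs from compound 2 at the same sulfur: a group of 5 heavy atoms (3 carbon, 1 nitrogen, 1 sulfur; one five-membered non-aromatic ring with 2 hetero atoms) in place of a group of 6 heavy atoms (2 carbon, 4 nitrogen; one five-membered aromatic ring with 4 hetero atoms), on a sulfur. Among the compounds with values here, the only measured step that bears on this place, a number 23.7 percentage points higher from compound 1 to compound 2 (beyond the scatter), shows that swapping the group on the sulfur can move the read-out well beyond the scatter, but it involved other groups, so its direction gives no firm guide for compound 3. Since the entering group lacks the aromatic ring rich in nitrogen that compound 2 carries, the expected step is a modest fall, a number 13.7 percentage points lower from compound 2 to compound 3 (beyond the scatter), with wide uncertainty. Compound 3 is therefore estimated to give 50% in this assay, within a range from 28% to 72%.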

Compound 3, a percentage reported as activity, at one concentration (the size of the read-out at that concentration, not a potency): 41.8%
For compound 3 the middle estimate is 8.2 percentage points above the measured one, within the range that was stated.
By their numbers in this assay, from the lowest: compounds 1 and 3 (each within the scatter of the next); then compound 2.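

In this assay, the exchange on this sulfur gives a number 21.9 percentage points lower from compound 2 to compound 3 (beyond the scatter), which shows that the high read-out of compound 2 does not carry over to every small five-membered ring in this place. The step of a number 1.8 percentage points higher from compound 1 to compound 3 (within the scatter) adds a second point: a group of 5 heavy atoms with a non-aromatic ring and the 5-chloro-1,3-benzoxazol-2-yl group of 10 heavy atoms leave the read-out within the scatter, so neither group count nor the presence of an aromatic ring separates these two compounds, and among the three groups only 1-methyl-1H-tetrazol-5-yl stands apart. No supporting information bears on why this group differs from the other two.

The compounds shown leave open whether the higher read-out depends on the tetrazole ring itself or on its methyl group, a question that a 1-phenyl-1H-tetrazol-5-yl or a 1,2,4-triazol-3-yl group on the same sulfur would address. They also leave open how a carboxylic acid or an amine on this sulfur's chain would compare, and, with a read-out at one concentration, how the compounds rank in potency.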